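The compounds below may be only part of what the source reports. "The series", "measured", "known", "first", "only" and "open" are said of these compounds alone.

Going by the values given here, compound 2, `O=C(CCCCC1CCSS1)NCc1cn(CCCCOc2ccc3cc(-c4ccccc4)c(=O)oc3c2)nn1`, stands at the lower end of the two numbers known so far: in a functional assay on PC-12 cells (Rattus norvegicus) for cytotoxicity, read by MTT assay, with stated times of 3 h and 2 h, tested at 10 uM (a higher number here means a stronger effect of the compound at the concentration tested, a lower number a weaker effect), compound 2 gives 30.5%, whereas compound 1, `O=C(CCCCC1CCSS1)NCc1cn(CCCCOc2ccc3ccc(=O)oc3c2)nn1`, gives 65.1%. Among the compounds with values here, the only measured step between the two, a number 34.6 percentage points lower from compound 1 to compound 2 (beyond the scatter), came with a phenyl in place of hydrogen on an aromatic carbon.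

Compound 3, `COc1ccc(-c2cc3ccc(OCCCCn4cc(CNC(=O)CCCCC5CCSS5)nn4)cc3oc2=O)cc1`, departs from compound 2 by a different and smaller change: methoxy in place of hydrogen on an aromatic carbon. Within the data shown here, no measured step follows a methoxy entering on such a carbon, so the one step on record offers only a loose guide. That step was large, yet it concerned a phenyl ring, not a two-atom group added onto that ring; the record gives no ground to expect either a further fall or a return toward compound 1.

Compound 3 is therefore expected to sit close to compound 2, with a step of about a number 2.5 percentage points lower from compound 2 to compound 3 (within the scatter) in this assay, within the scatter. Compound 3 is estimated at 28%, most likely between 10% and 50%.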

Compound 3, a percentage reported as activity, at one concentration (the size of the read-out at that concentration, not a potency): 48.6%
For compound 3 the middle estimate is 20.6 percentage points below the measured one; the range from low to high includes it.
By their numbers in this assay, from the lowest: compound 2; then compound 3; then compound 1.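

In this assay, the phenyl ring added in compound 2 does not set a fixed level for the series, as a change on that ring alone moves the result: methoxy on an aromatic carbon of the ring, para to a large group, gives a number 18.1 percentage points higher from compound 2 to compound 3 (beyond the scatter) and so takes back part of the drop that came with phenyl. The recovery is only partial, as the full 4-methoxyphenyl group in place of hydrogen on the core of compound 1 still leaves a number 16.5 percentage points lower from compound 1 to compound 3 (beyond the scatter) in the same assay. This position therefore tolerates more than one outcome, and its substituent, not only the presence of an aryl ring, matters here, although no measurement at hand explains why the number rises with methoxy.

From the compounds shown here alone, whether this rise is particular to methoxy remains open, as a hydroxy group, an amine or a fluorine atom on the same ring carbon might move the number differently. Also open, going by these compounds, is whether the same step would hold with a longer chain in the linker or with methoxy on another carbon of that ring.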